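The compounds below may be only part of what the source reports. "The series", "measured", "known", "first", "only" and "open" are said of these compounds alone.

Of the compounds shown here, three built on one shared core have been measured in a functional assay on SK-N-SH cells (Homo sapiens) for inhibition, read by MTT assay, with a stated time of 72 h; a higher number here means a weaker inhibitor, a lower number a stronger inhibitor. Compound 1 `O=C(/C=C/c1cccs1)c1ccc(OCCSC(=S)N2CCCC2)cc1` gives 19100 nM. Compound 3 `COc1cc(/C=C/C(=O)c2ccc(OCCCSC(=S)N3CCCC3)cc2)cc(OC)c1OC` gives 12800 nM. Compound 2 `COc1ccc(/C=C/C(=O)c2ccc(OCCCSC(=S)N3CCN(C)CC3)cc2)cc1` gives 29500 nM, the highest number of the three; the number for compound 1 lies within the usual scatter of it, while the number for compound 3 is lower by more than the scatter. Compound 4 `CN1CCN(C(=S)SCCCOc2ccc(C(=O)/C=C/c3cc(F)cc(F)c3)cc2)CC1` has not been measured. It differs from compound 2 in one place: 3,5-difluorophenyl in place of 4-methoxyphenyl on a double-bonded chain carbon bound to a double-bonded chain carbon. Going by the values given here, no measured pair shows this change, so its effect is unknown. The three measured numbers sit fairly close together. The step of a 1.3-fold lower number from compound 2 to compound 4 (0.13 log units; within the scatter) is expected to be small, with no clear direction beyond the scatter. Compound 4 is thus expected to give about 22000 nM in this assay, within a range from 8000 nM to 60000 nM.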

Compound 4, half-maximal inhibitory concentration: 13200 nM
Estimate against measurement, compound 4: 1.7-fold (0.22 log units) above; low and high end bracket the measured number.
By their numbers in this assay, from the lowest: compounds 3, 4, 1 and 2 (each within the scatter of the next, the first and the last beyond it).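

In this assay, going by these compounds alone, replacing 4-methoxyphenyl with 3,5-difluorophenyl on a double-bonded chain carbon bound to a double-bonded chain carbon gives a 2.2-fold lower number from compound 2 to compound 4 (0.35 log units; beyond the scatter), the only one-place step available so far. It shows that the group at this position can move the number beyond the usual scatter, though only modestly, and that the difluorinated ring gives the stronger inhibitor of this pair. No measurement here explains the change. Still open, from the compounds shown here alone, is how unsubstituted phenyl, 3-fluorophenyl or a pyridine ring would behave at this position. It is also unknown whether the same swap has a similar effect when the rest of the molecule differs.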